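The source may hold more compounds than are shown below. What is called first, only, known or untested is meant among the compounds shown, and "the series" means these compounds.

Compound 2 `COc1ccc(-c2cn(C(C)=O)c(=O)n2-c2cc(OC)c(OC)c(OC)c2)cc1` stands highest of the two values in a functional assay on K-562R cells (Homo sapiens) for cytotoxicity, read by MTT assay, with a stated time of 48 h (a lower number here means a stronger inhibitor, a higher number a weaker inhibitor), where compound 2 gives 9500 nM. For the measured compounds named here, its only measured neighbour, compound 1 `COc1cc(-n2c(-c3ccc(Br)cc3)cn(C(C)=O)c2=O)cc(OC)c1OC`, gives 900 nM in this assay, the step being an 11-fold higher number from compound 1 to compound 2 (1.02 log units; beyond the scatter) for methoxy in place of bromo on an aromatic carbon. Compound 3 `COc1ccc(-c2cn(C(C)=O)c(=O)n2-c2cc(OC)c(OC)c(OC)c2)cc1[N+](=O)[O-]` differs from compound 2 by nitro in place of hydrogen on an aromatic carbon. Going by the values given here, no measured step touches a nitro group, so the large step of an 11-fold higher number from compound 1 to compound 2 (1.02 log units; beyond the scatter) does not bear on this change; the analyst expects a step of a 1.2-fold lower number from compound 2 to compound 3 (0.07 log units; within the scatter), within the scatter. Compound 3 is therefore estimated at 8000 nM, between 2500 nM and 25000 nM.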

Compound 3, half-maximal inhibitory concentration: > 50000 nM
Compound 3 was reported as a limit; the forecaster's own chance of this, stated with the estimate: 10%; at least 6.2-fold (0.79 log units) between middle value and limit.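

In this assay, compound 3 is reported only as a limit, > 50000 nM. Nitro in place of hydrogen gives an at least 5.2-fold higher number from compound 2 to compound 3 (0.72 log units; beyond the scatter), so this ring carbon, ortho to a methoxy group, is not indifferent to substitution, whereas the earlier step showed only a swap of bromo for methoxy on a different carbon. The true size of this step remains unknown, as the reading rests on a limit: the limit of > 50000 nM in this assay, at which 1 of the 3 values shown sits.

The compounds shown leave open whether this weakening belongs to nitro itself or would also follow from a smaller group such as fluoro. They also leave open how an amine or a hydroxyl group would read on this carbon.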